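A few compounds are considered here, and "the series" means these few. Any claim that something is new, unique, unknown or untested is made for them only; others in the source may bear on it.

Compound 1 `O=C(NCCCNc1nc(Nc2cccc(F)c2)ncc1Br)c1cccs1` gives 9 nM in an assay on isolated protein for inhibition of serine/threonine-protein kinase TBK1 (Homo sapiens); a lower number here means a stronger inhibitor, a higher number a weaker inhibitor. Among the three measured compounds it stands second highest: compound 2 `O=C(NCCCNc1nc(Nc2ccc(-n3cncn3)cc2)ncc1C1CC1)C1CCC1` gives 3 nM, and compound 3 `O=C(NCCCNc1nc(Nc2cccc(F)c2)ncc1C1CC1)c1cccs1` gives 110 nM. Going by the values given here, the only single-point step measured so far, a 12-fold higher number from compound 1 to compound 3 (1.09 log units; beyond the scatter), concerns a different part of the shared core and so does not bear on the change considered here. Compound 4 `CN1CCC(C(=O)NCCCNc2nc(Nc3cccc(F)c3)ncc2Br)CC1` differs from compound 1 by 1-methylpiperidin-4-yl in place of thiophen-2-yl on a carbonyl carbon. Among the compounds with values here, no measured step tests this exact change; compound 2 does carry a non-aromatic ring on the carbonyl carbon and gives a low number, though it differs elsewhere as well. For compound 4 a step of a 1.1-fold higher number from compound 1 to compound 4 (0.05 log units; within the scatter) is therefore expected, lying within the scatter. Compound 4 is estimated at 10 nM, between 3 nM and 40 nM.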

Compound 4, half-maximal inhibitory concentration: 4300 nM
The estimate for compound 4 lay 430-fold (2.63 log units) below the measured number; the measured number lies above the stated range.
By their numbers in this assay, from the lowest: compound 2; then compound 1; then compound 3; then compound 4.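

Swapping thiophen-2-yl for 1-methylpiperidin-4-yl on the carbonyl carbon gives a 480-fold higher number from compound 1 to compound 4 (2.68 log units; beyond the scatter) and so turns a strong inhibitor into a weak one. Going by these compounds alone, no earlier step tested this position, and the result shows that the group on this carbonyl carbon can strongly change the number. Nothing measured here accounts for the size of this step. On these data alone, it remains open whether the ring nitrogen with its methyl or the loss of the aromatic ring matters more. A cyclohexyl or phenyl group on the same carbonyl carbon would help separate the two.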